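This account rests on a few compounds, and the source may have more. Where it says the series, first, only, none or still open, it means among the compounds named here.

In a functional assay on CWR22R cells (Homo sapiens) for antiproliferative activity, read by propidium iodide staining, with a stated time of 96 h (a higher number here means a weaker inhibitor, a lower number a stronger inhibitor), the three measured compounds gave these results:

Compound 1 `CC(O)(CSc1cccc(S(F)(F)(F)(F)F)c1)C(=O)Nc1ccc(C#N)cc1C(F)(F)F`: 21600 nM
Compound 2 `CC(O)(CSc1cccc(S(F)(F)(F)(F)F)c1)C(=O)Nc1ccc([N+](=O)[O-])cc1C(F)(F)F`: 17500 nM
Compound 3 `CC1(C)C(=O)N(c2ccc(C#N)cc2C(F)(F)F)C(=S)N1c1ccc(S(F)(F)(F)(F)F)cc1`: 5400 nM

Compound 3 has the lowest of the three numbers, and its steps to compound 2 and to compound 1 are both beyond the scatter. The difference between the core of compound 3 and the core of compound 1 is not broken down here. Compound 2 differs from compound 1 by nitro in place of cyano on an aromatic carbon, and that change gave a 1.2-fold lower number from compound 1 to compound 2 (0.09 log units; within the scatter). Compound 4 `CC1(C)C(=O)N(c2ccc([N+](=O)[O-])cc2C(F)(F)F)C(=S)N1c1ccc(S(F)(F)(F)(F)F)cc1`, not yet measured, differs from compound 3 by the same change, (nitro in place of cyano on an aromatic carbon), at a place described in the same words. Going by the values given here, because the only measured instance of this change is a 1.2-fold lower number from compound 1 to compound 2 (0.09 log units; within the scatter), the step expected for compound 4 is a 1.2-fold lower number from compound 3 to compound 4 (0.08 log units; within the scatter). In this assay compound 4 is therefore estimated at 4500 nM, most likely between 2000 nM and 11000 nM.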

Compound 4, half-maximal inhibitory concentration: 100000 nM
Estimate against measurement, compound 4: 22-fold (1.35 log units) below, outside the stated range (above it).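

In this assay, going by these compounds alone, nitro in place of cyano on the core of compound 3 gave a 19-fold higher number from compound 3 to compound 4 (1.27 log units; beyond the scatter), and the two cores did not respond alike: the same change on two cores in this assay, a 1.2-fold lower number (0.09 log units; within the scatter) from compound 1 to compound 2 and a 19-fold higher number (1.27 log units; beyond the scatter) from compound 3 to compound 4, 23-fold (1.36 log units) apart, beyond the scatter of two such steps On these two pairs, then, the step measured on one core was no guide to the step on the other. This does not show why the two cores differ, and two pairs give no general rule for the series.

The compounds shown leave open how an amine or a carboxylic acid on that same aromatic carbon would behave on either core. They also leave open whether such groups would split between the cores as nitro and cyano do.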